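Sulfonyl aryl variation in the nitro-indole hydrazone series

The source may hold more compounds than are shown below. What is called first, only, known or untested is meant among the compounds shown, and "the series" means these compounds.

The three measured compounds share one core and differ only in the aryl group on the sulfonyl sulfur. In a functional assay on HEK293 cells for inhibition of 5-hydroxytryptamine receptor 6 (Homo sapiens), read by calcium flux and cAMP accumulation, with a stated time of 10 min (a lower number here means a stronger inhibitor, a higher number a weaker inhibitor), compound 1 `CN(C)/C=N/N=C/c1cn(S(=O)(=O)c2ccc(I)cc2)c2cccc([N+](=O)[O-])c12` gives 6340 nM, compound 2 `COc1ccc(OC)c(S(=O)(=O)n2cc(/C=N/N=C/N(C)C)c3c([N+](=O)[O-])cccc32)c1` gives 1400 nM, and compound 3 `COc1ccc(Cl)cc1S(=O)(=O)n1cc(/C=N/N=C/N(C)C)c2c([N+](=O)[O-])cccc21` gives 2440 nM. Compound 3 thus stands second highest of the three numbers: against compound 2 the gap is within the scatter, while against compound 1 it is beyond it.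

Compound 4 `CN(C)/C=N/N=C/c1cn(S(=O)(=O)c2cccc3ccccc23)c2cccc([N+](=O)[O-])c12` carries the change (naphthalen-1-yl in place of 5-chloro-2-methoxyphenyl on a sulfonyl sulfur). Going by the values given here, the steps that bear on it are those that also replaced the aryl group on the sulfonyl sulfur: a 4.5-fold lower number from compound 1 to compound 2 (0.66 log units; beyond the scatter) and a 2.6-fold lower number from compound 1 to compound 3 (0.41 log units; beyond the scatter), both modest, and a 1.7-fold higher number from compound 2 to compound 3 (0.24 log units; within the scatter), within the scatter. Among the compounds with values here, no measured compound carries a second fused aromatic ring at this position, so the direction of the step is not well fixed. With aryl exchanges so far giving at most modest shifts, a step of about a 1.2-fold lower number from compound 3 to compound 4 (0.09 log units; within the scatter) is expected. Compound 4 is therefore estimated at 2000 nM, with a range from 600 nM to 7000 nM.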

Compound 4, half-maximal inhibitory concentration: 2960 nM
Estimate against measurement, compound 4: 1.5-fold (0.17 log units) below; low and high end bracket the measured number.
By their numbers in this assay, from the lowest: compounds 2, 3 and 4 (each within the scatter of the next, the first and the last beyond it); then compound 1.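

Compound 4 brings a second six-membered aromatic ring onto the sulfonyl sulfur and removes the hydrogen-bond acceptor of the leaving group, yet this assay does not separate it from compound 3: a 1.2-fold higher number from compound 3 to compound 4 (0.08 log units; within the scatter). The group is still not equivalent to the other aryl groups, with a 2.1-fold higher number from compound 2 to compound 4 (0.33 log units; beyond the scatter) and a 2.1-fold lower number from compound 1 to compound 4 (0.33 log units; beyond the scatter), both modest steps, so naphthalen-1-yl falls within the narrow span already set by the single-ring groups. No measurement shown gives a reason for these differences.

Going by these compounds, all four compounds carry an aryl group on the sulfonyl sulfur, so it remains open how an aliphatic amine or a carboxylic acid at this position would read out. On these data alone, whether a naphthalene attached through another ring carbon matches naphthalen-1-yl also remains open.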